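The source may report more compounds than this note shows. Statements on the series, on what has been measured and on what is new or still open speak of the compounds shown alone.

Three compounds have been measured in a functional assay on HT-29 cells (Homo sapiens) for cytotoxicity, read by sulforhodamine B assay, with a stated time of 2 days, tested at 100 uM; on this read-out higher numbers stand for more inhibition at the one concentration tested (going by the name of the read-out) and lower numbers for less inhibition:

compound 3 `O=C(Nn1c(-c2cccc([N+](=O)[O-])c2)nc2c(-c3ccc(Cl)cc3)n[nH]c2c1=O)c1ccccc1` gives 87.8%
compound 1 `O=C(Nn1c(-c2cccc([N+](=O)[O-])c2)nc2c(CCc3ccccc3)n[nH]c2c1=O)c1cccnc1` gives 20.1%
compound 2 `CCCc1n[nH]c2c(=O)n(NC(=O)c3ccccc3)c(-c3cccc([N+](=O)[O-])c3)nc12` gives 18.7%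

Compound 3 stands highest of the three, and its distance from each of the other two lies beyond the scatter. Compound 4 `O=C(Nn1c(-c2cccc([N+](=O)[O-])c2)nc2c(CCc3ccccc3)n[nH]c2c1=O)c1ccccc1` differs from compound 3 by phenethyl in place of 4-chlorophenyl on an aromatic carbon. Among the compounds with values here, one measured step bears on this change: a number 69.1 percentage points higher from compound 2 to compound 3 (beyond the scatter), where an aromatic ring took the place of a chain on that aromatic carbon. Compound 4 goes back to a chain there, and compound 1, which carries phenethyl on that carbon as well, gives 20.1% in this assay. A large fall is therefore expected, a number 65.8 percentage points lower from compound 3 to compound 4 (beyond the scatter). Compound 4 is estimated at 22%, with a range from 5% to 45%.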

Compound 4, a percentage reported as inhibition, at one concentration (the size of the read-out at that concentration, not a potency): 89.7%
The estimate for compound 4 lay 67.7 percentage points below the measured number, and the stated range ends below it.
By their numbers in this assay, from the lowest: compounds 2 and 1 (each within the scatter of the next); then compounds 3 and 4 (each within the scatter of the next).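

In this assay, phenethyl and 4-chlorophenyl on this aromatic carbon cannot be told apart, a number 1.9 percentage points higher from compound 3 to compound 4 (within the scatter), so a chain there does not by itself bring a low number. The phenyl at the chain's end matters, a number 71 percentage points higher from compound 2 to compound 4 (beyond the scatter), and the low number of compound 1 goes with its pyridin-3-yl on the carbonyl carbon, a number 69.6 percentage points higher from compound 1 to compound 4 (beyond the scatter). Nothing measured here explains these steps. Open, going by these compounds, is how a longer chain ending in phenyl would read, and whether pyridin-3-yl also lowers the number when 4-chlorophenyl sits on the aromatic carbon.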